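Swapping a methyl for a cyano on the biphenyl core

A few compounds are considered here, and "the series" means these few. Any claim that something is new, unique, unknown or untested is made for them only; others in the source may bear on it.

Measured compounds:
- compound 1, `Oc1ccccc1CNc1ccc(-c2ccccc2)cc1`: 1820 nM
- compound 2, `Oc1ccccc1CNc1ccc(-c2ccccc2F)cc1`: 2150 nM
- compound 3, `Cc1ccccc1-c1ccc(NCc2ccccc2O)cc1`: 5220 nM

These three compounds share a common core and differ only in one substituent on the outer aromatic ring. In a functional assay on Jurkat cells (Homo sapiens) for activation, with a stated time of 24 h (on this read-out lower numbers stand for an effect already at smaller amounts and higher numbers for an effect only at larger amounts of compound), compound 3 stands highest of the three numbers; the nearest is compound 2, with a 2.4-fold higher number from compound 2 to compound 3 (0.39 log units; beyond the scatter), and the furthest is compound 1, with a 2.9-fold higher number from compound 1 to compound 3 (0.46 log units; beyond the scatter). By contrast, a 1.2-fold higher number from compound 1 to compound 2 (0.07 log units; within the scatter), so the fluoro compound and the unsubstituted compound cannot be told apart here.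

Compound 4, `N#Cc1ccccc1-c1ccc(NCc2ccccc2O)cc1`, is the unmeasured partner. The change is cyano in place of methyl on an aromatic carbon. Among the measured compounds shown here, no measured step puts a cyano on this ring, so the closest guidance comes from the two methyl steps, both modest and both toward higher numbers, while the fluoro step stayed within the scatter. A cyano is neither a methyl nor a fluoro, so the expectation is loose: a step of about a 1.3-fold lower number from compound 3 to compound 4 (0.12 log units; within the scatter) is expected, most likely within the scatter or only modestly toward a lower number. Compound 4 is therefore estimated at 4000 nM in this assay, with a range from 1500 nM to 11000 nM.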

Compound 4, half-maximal effective concentration: "not active" (no number reported)
For compound 4 the study gives words and no number, so the estimate cannot be set against anything.
By their numbers in this assay, from the lowest: compounds 1 and 2 (each within the scatter of the next); then compound 3.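

In this assay, among the compounds shown here, compound 4 is reported only in words, as not active, so no step from compound 3 or any other compound can be read. Nothing shown offers an explanation for this result. The compounds shown leave open how far compound 4 lies from compound 3 on this read-out.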